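This account rests on a few compounds, and the source may have more. Where it says the series, first, only, none or still open, it means among the compounds named here.

Going by the values given here, in a functional assay on A549 cells (Homo sapiens) for antiproliferative activity, read by MTT assay, with a stated time of 48 h (a lower number here means a stronger inhibitor, a higher number a weaker inhibitor), compound 2 `CCc1ccccc1-n1nncc1CN1C(=O)C2(C(C#N)=C(N)Oc3c(N)cc4nc5ccccc5nc4c32)c2ccccc21` gives 24600 nM, the only number among the values shown. Compound 1 `N#CC1=C(N)Oc2c(c3nc4ccccc4nc3c3ccccc23)C12C(=O)N(Cc1cnnn1-c1ccc(F)c(Cl)c1)c1ccccc12` reports only a limit in this assay, > 50000 nM. That sits at the limit of > 50000 nM in this assay, at which 1 of the 2 values shown sits. Compound 3 `Cc1ccc(-n2nncc2CN2C(=O)C3(C(C#N)=C(N)Oc4c(N)cc5nc6ccccc6nc5c43)c3ccccc32)cc1Cl` carries 3-chloro-4-methylphenyl in place of 2-ethylphenyl on an aromatic nitrogen. Among the compounds with values here, no step between measured compounds is available, so the step of a 1.0-fold higher number from compound 2 to compound 3 (0.01 log units; within the scatter) is expected to stay within the usual scatter, with no clear direction. In this assay compound 3 is therefore estimated at 25000 nM, with a likely range from 10000 nM to 60000 nM, and a real chance that only a limit is returned.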

Compound 3, half-maximal inhibitory concentration: 11800 nM
Beside the measured number, compound 3's estimate is 2.1-fold (0.33 log units) above it, within the range that was stated.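

At the aromatic nitrogen of the five-membered ring, in this assay, the change to 3-chloro-4-methylphenyl from 2-ethylphenyl brings a 2.1-fold lower number from compound 2 to compound 3 (0.32 log units; beyond the scatter), so this position does respond to the aryl group, if only modestly. The step comes with no change in the count of heavy atoms. No measurement given here bears on what drives it. On these data alone, whether the chlorine or the methyl carries the step remains open, as does the effect of an amine or a carboxylic acid on that phenyl ring.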